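The compounds below may be only part of what the source reports. "The series", "measured", "known", "first", "only" and "open" are said of these compounds alone.

Measured in a functional assay on A2780 cells (Homo sapiens) for antiproliferative activity, read by sulforhodamine B assay, with a stated time of 48 h; on this read-out lower numbers stand for stronger inhibition of growth and higher numbers for weaker inhibition of growth:

compound 1 `CC(C)C/C=C/C(=O)CC(O)CC(C)C`: 17000 nM
compound 2 `O=C(/C=C/c1ccccc1)CC(O)c1ccccc1`: 3300 nM
compound 3 `CC(C)CC(O)CC(=O)/C=C\c1ccccc1`: 2600 nM

Compound 3 carries the lowest of the three numbers shown in this assay. Its gap to compound 2 is within the usual scatter, so the two cannot be told apart on these data; its gap to compound 1 is beyond the scatter, compound 1 standing well higher. Within the data shown here, no pair among the measured compounds differs in one place only, so no measured step is available to calibrate the change that follows.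

Compound 4 `Cc1ccc(/C=C\C(=O)CC(O)CC(C)C)cc1` is the next member to be measured. It differs from compound 3 by methyl in place of hydrogen on an aromatic carbon. Among the measured compounds shown here, nothing among the measured compounds shows what a methyl on that ring does, so the expectation rests on the change being small and without donors or acceptors. A step in this assay of no more than the usual scatter is expected, in either direction, with no firm lean. For compound 4 the value in this assay is accordingly estimated at 2500 nM, with a range of 1000 nM to 6500 nM. The step this estimate means, a 1.0-fold lower number from compound 3 to compound 4 (0.02 log units; within the scatter), is expected to stay within the scatter.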

Compound 4, concentration for 50% growth inhibition: 3900 nM
Beside the measured number, compound 4's estimate is 1.6-fold (0.19 log units) below it, and the stated range covers the measured number.
By their numbers in this assay, from the lowest: compounds 3, 2 and 4 (each within the scatter of the next); then compound 1.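

In this assay, among these compounds, methyl in place of hydrogen on an aromatic carbon, para to a large group, gives a 1.5-fold higher number from compound 3 to compound 4 (0.18 log units; within the scatter), the only step in this set between compounds that differ in one place. The aromatic position therefore accepts this one-carbon addition with no change that can be separated from the usual variation between repeated measurements, and the step sets no direction for the series at this position. The data offer no information that bears on the size of this step.

Going by these compounds, it remains open whether a group other than methyl at this same place, such as methoxy, a chlorine atom, an amine or a carboxylic acid, would carry the number beyond the scatter, and whether methyl on other carbons of the ring would behave like methyl here. Also open, on these data alone, is whether the same methyl change would give a step of similar size on the core of compound 2, since this single step from the core of compound 3 cannot be carried over to another core.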